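Exchanging a five-membered ring in an antiproliferative series

A few compounds are considered here, and "the series" means these few. Any claim that something is new, unique, unknown or untested is made for them only; others in the source may bear on it.

Compound 1 `CC/C(=C(/c1ccc(/C=C/C(=O)O)cc1)c1ccc(-c2nccs2)cc1)c1ccccc1`: 290 nM
Compound 2 `CC/C(=C(/c1ccc(/C=C/C(=O)O)cc1)c1ccc(-c2cnn(C)c2)cc1)c1ccccc1`: 80 nM

Both compounds were tested in a functional assay on MCF7 cells (Homo sapiens) for antiproliferative activity, read by CellTiter-Glo, with a stated time of 5 days; on this read-out higher numbers stand for weaker inhibition and lower numbers for stronger inhibition. Compound 2 stands lower of the two at 80 nM, which makes it the stronger inhibitor so far.

The next compound, compound 3 `CC/C(=C(/c1ccc(/C=C/C(=O)O)cc1)c1ccc(-n2ccnc2)cc1)c1ccccc1`, has not yet been measured. It keeps the shared core and changes one group: 1H-imidazol-1-yl in place of 1-methyl-1H-pyrazol-4-yl on an aromatic carbon. In plain terms, 1H-imidazol-1-yl replaces 1-methyl-1H-pyrazol-4-yl on an aromatic carbon.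

Going by the values given here, only one measured step bears on this change, and it also exchanges one five-membered aromatic ring for another: a 3.6-fold lower number from compound 1 to compound 2 (0.56 log units; beyond the scatter). Among the compounds with values here, that modest step shows that such a swap can move the number, but a single step sets no rule, and no measured compound carries 1H-imidazol-1-yl. In this assay, within the data shown here, a step of that size or smaller is therefore expected, more likely toward a higher number, as compound 2 at 80 nM holds the lower of only two values. The expected change is a 1.9-fold higher number from compound 2 to compound 3 (0.27 log units; within the scatter). For compound 3 the estimated value is 150 nM, with an expected range of 50 nM to 450 nM.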

Compound 3, half-maximal inhibitory concentration: 380 nM
For compound 3 the middle estimate is 2.5-fold (0.40 log units) below the measured one; low and high end bracket the measured number.
By their numbers in this assay, from the lowest: compound 2; then compounds 1 and 3 (each within the scatter of the next).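

In this assay, this position para to a large group tells apart two rings that look alike on paper. Both 1-methyl-1H-pyrazol-4-yl and 1H-imidazol-1-yl are one five-membered aromatic ring with 2 hetero atoms and the same counts of hydrogen-bond donors and acceptors, yet the exchange gives a 4.8-fold higher number from compound 2 to compound 3 (0.68 log units; beyond the scatter). Compound 3 also sits level with the thiazole-bearing compound, at a 1.3-fold higher number from compound 1 to compound 3 (0.12 log units; within the scatter), so 1H-imidazol-1-yl and 1,3-thiazol-2-yl cannot be told apart here, and among these three rings only the 1-methyl-1H-pyrazol-4-yl of compound 2 stands apart, with the lowest number; nothing available explains this difference.

The compounds shown leave open whether the advantage of compound 2 depends on its methyl group, since no compound here carries an unsubstituted 1H-pyrazol-4-yl ring, or a longer chain such as ethyl on that ring nitrogen. They also leave open how a six-membered ring such as pyridinyl, or a small open-chain group such as an amine, would compare at this position.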